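This account rests on a few compounds, and the source may have more. Where it says the series, first, only, none or still open, it means among the compounds named here.

Measured so far:

Compound 1, `Clc1ccc2nc(-c3ccccn3)c(Nc3ccc4c(c3)OCCO4)n2c1`, in an ADME assay on THP-1 cells (Homo sapiens) for cytotoxicity (on this read-out lower numbers stand for higher toxicity in this test and higher numbers for lower toxicity in this test), gives > 50000 nM, which is a limit of the assay and not a number.
Compound 2, `COCc1ccn2c(Nc3cccc(F)c3)c(-c3ccccn3)nc2c1`, in this assay gives 7370 nM.

For the measured compounds named here, compound 2 is the only compound in this set with an actual number; the value of compound 1 is the limit of > 50000 nM in this assay, at which 1 of the 2 values shown sits, so nothing can be said about how far the two compounds lie apart. Going by the values given here, with a single number and a single limit, no step between measured compounds can be sized.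

The step followed here leads from compound 2 to compound 3, `Cc1ccn2c(Nc3cccc(F)c3)c(-c3ccccn3)nc2c1`. The change is hydrogen in place of methoxy on a saturated chain carbon bound to an aromatic carbon, so that a methoxymethyl group becomes a methyl group. The rest of the molecule, including the fluorophenyl amine and the pyridyl group on the shared core, stays the same.

Among the compounds with values here, no measured step of this kind is available to lean on. In this assay the expectation is a change no larger than the usual scatter, in either direction, giving an expected step of a 1.1-fold lower number from compound 2 to compound 3 (0.02 log units; within the scatter). Compound 3 is therefore estimated at 7000 nM, with a range from 2500 nM to 20000 nM.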

Compound 3, half-maximal cytotoxic concentration: 14200 nM
The estimate for compound 3 lay 2.0-fold (0.31 log units) below the measured number; measured number inside the range.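

Turning the methoxymethyl group into a methyl group gives a 1.9-fold higher number from compound 2 to compound 3 (0.28 log units; within the scatter), so in this assay compounds 2 and 3 cannot be told apart. For the compounds shown here, this is the first view of this position, which the earlier pair could not give, since compound 1 differs from compound 2 in more than one place. For this one pair, with the fluorophenyl amine and the pyridyl group held the same, the methoxy group and its oxygen can give way to hydrogen on the saturated chain carbon bound to an aromatic carbon, and the number stays within the ordinary spread of repeat measurements, so nothing shown here gives a reason for the small step.

Going by these compounds, whether other groups at this place, such as an amine, a carboxylic acid or a longer chain, would move the number beyond that spread remains open. On these data alone, it is also open whether the same replacement of methoxy by hydrogen would behave alike on a compound carrying a different amine on the shared core, since a single pair sets no rule.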